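From Dichlorophenyl to Dihydroxyphenyl in a Cytotoxic Series

The compounds below may be only part of what the source reports. "The series", "measured", "known", "first", "only" and "open" are said of these compounds alone.

Among the compounds with values here, in a functional assay on HT-1080 cells (Homo sapiens) for cytotoxicity, read by MTT assay, with a stated time of 72 h (a lower number here means a stronger inhibitor, a higher number a weaker inhibitor), compound 1 `COc1ccc(/C=C2\CCC/C(=C\c3cccc(Cl)c3Cl)C2=O)cc1OC` gives 8800 nM and compound 2 `COc1ccc(/C=C2\CCC/C(=C\c3cc(Cl)cc(Cl)c3)C2=O)cc1OC` gives 3000 nM, the lower of the two numbers so far. Within the data shown here, the one measured step, a 2.9-fold lower number from compound 1 to compound 2 (0.47 log units; beyond the scatter), comes from 3,5-dichlorophenyl in place of 2,3-dichlorophenyl and is modest, though beyond the scatter.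

Compound 3 `COc1ccc(/C=C2\CCC/C(=C\c3ccc(O)c(O)c3)C2=O)cc1OC` changes the same place, on a double-bonded chain carbon bound to a double-bonded ring carbon, with 3,4-dihydroxyphenyl in place of 3,5-dichlorophenyl on a double-bonded chain carbon bound to a double-bonded ring carbon. Among the measured compounds shown here, this is a different kind of change from the measured one, since the chlorine atoms leave altogether, and no measured compound carries the entering group. The step from compound 1 therefore offers only a rough guide to size and gives no direction. With a 2.9-fold lower number from compound 1 to compound 2 (0.47 log units; beyond the scatter) as the sole reference, no large shift is expected. The expected change, a 1.2-fold lower number from compound 2 to compound 3 (0.08 log units; within the scatter), is estimated to stay within the scatter. Compound 3 is estimated at 2500 nM in this assay, with 700 nM to 9000 nM as its expected range.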

Compound 3, half-maximal inhibitory concentration: 4200 nM
Estimate against measurement, compound 3: 1.7-fold (0.23 log units) below; measured number inside the range.
By their numbers in this assay, from the lowest: compounds 2 and 3 (each within the scatter of the next); then compound 1.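

In this assay, the place on a double-bonded chain carbon bound to a double-bonded ring carbon accepts a phenyl group with no chlorine at all: 3,4-dihydroxyphenyl in place of 3,5-dichlorophenyl gives a 1.4-fold higher number from compound 2 to compound 3 (0.15 log units; within the scatter), so the chlorine atoms are not required for a number in this range. Set against the 2,3-dichlorophenyl group, the same 3,4-dihydroxyphenyl group gives a 2.1-fold lower number from compound 1 to compound 3 (0.32 log units; beyond the scatter), a modest step, which leaves compound 1 apart from the other two and shows that the dichlorophenyl groups do not form a single class here. No measurement of any property of these groups is available to account for these numbers.

The compounds shown leave open whether 3,4-dichlorophenyl, 3,4-dimethoxyphenyl or plain phenyl at this place would sit with compounds 2 and 3 or with compound 1, and so whether the hydroxyl groups themselves matter at all. They also leave open what an amine or a carboxylic acid on this phenyl ring would do, and how the numbers respond to any change in the 3,4-dimethoxyphenyl group that all three compounds share.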